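The source may report more compounds than this note shows. Statements on the series, on what has been measured and on what is new or still open speak of the compounds shown alone.

Measured compounds:
compound 1, `Cc1cccc(NC2=C(Nc3cccc(C)c3)C(=O)c3ccccc3C2=O)c1`, > 450000 nM
compound 2, `O=C1C(Nc2ccc(C(F)(F)F)cc2)=C(Nc2ccc(C(F)(F)F)cc2)C(=O)c2ccccc21`, 276000 nM
compound 3, `O=C1C(Nc2ccc(C(F)(F)F)cc2)=C(Nc2ccc(C(F)(F)F)cc2)C(=O)c2c1cccc2[N+](=O)[O-]`, 97000 nM

Notes on the series. In an ADME assay on L6 cells (Rattus norvegicus) for cytotoxicity, read by sulforhodamine B assay, with a stated time of 72 h (on this read-out lower numbers stand for stronger inhibition and higher numbers for weaker inhibition), compound 1 gives only a limit, > 450000 nM; this is the limit of > 450000 nM in this assay, at which 1 of the 3 values shown sits, not a number. Compound 2 gives 276000 nM and compound 3 gives 97000 nM in this assay. The measured step between them is a 2.8-fold lower number from compound 2 to compound 3 (0.45 log units; beyond the scatter), the change being (nitro in place of hydrogen on an aromatic carbon). How the core of compound 1 differs from that of compound 2 is not broken down here.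

Compound 4, `Cc1cccc(NC2=C(Nc3cccc(C)c3)C(=O)c3c(cccc3[N+](=O)[O-])C2=O)c1`, is still to be measured in this assay. It differs from compound 1 by nitro in place of hydrogen on an aromatic carbon, the same change as from compound 2 to compound 3, since both place descriptions agree word for word. Among the measured compounds shown here, on that basis a step about the size of the one seen from compound 2 to compound 3 is expected here. For compound 4 the expected step is an at least 1.8-fold lower number from compound 1 to compound 4 (0.25 log units; that floor lies within the scatter), though with compound 1 known only as a limit the starting point is uncertain. Compound 4 is therefore estimated at 250000 nM, between 100000 nM and 600000 nM, with a fair chance that this assay again reports only a limit.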

Compound 4, half-maximal inhibitory concentration: 195000 nM
The estimate for compound 4 lay 1.3-fold (0.11 log units) above the measured number; low and high end bracket the measured number.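

In this assay, nitro in place of hydrogen on an aromatic carbon gives an at least 2.3-fold lower number from compound 1 to compound 4 (0.36 log units; beyond the scatter), so the change lowers the number on the core of compound 1 as well as on the core of compound 2: the same change on two cores in this assay, a 2.8-fold lower number (0.45 log units; beyond the scatter) from compound 2 to compound 3 and an at least 2.3-fold lower number (0.36 log units; beyond the scatter) from compound 1 to compound 4; the limit leaves it open whether they differ

Compound 1 is known only as a limit, so the new step is a floor and its true size stays unknown: the limit of > 450000 nM in this assay, at which 1 of the 4 values shown sits.

The two pairs therefore show that the direction of the change carries from one core to the other, but they do not show that its size carries over, and two pairs make no general rule for the series.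

The compounds shown leave open whether an amine or a carboxylic acid in place of the nitro group would lower the number in the same way. Also open, from the compounds shown here alone, is how the nitro step behaves when chlorine or a methoxy group takes the place of the methyl or trifluoromethyl groups.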